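Compound 1 loses a methoxy group

The source may hold more compounds than are shown below. What is called first, only, known or untested is meant among the compounds shown, and "the series" means these compounds.

Values in a functional assay (Homo sapiens) for antiproliferative activity, read by sulforhodamine B assay, with a stated time of 48 h (on this read-out higher numbers stand for weaker inhibition and lower numbers for stronger inhibition), are as follows
compound 1 `COc1cc(NS(=O)(=O)c2ccc(N3CCNC3=O)cc2)cc(OC)c1OC` gives 58 nM
compound 2 `O=C1NCCN1c1ccc(S(=O)(=O)Nc2cccc(Br)c2)cc1` gives 270 nM
compound 3 `Cc1ccc(C)c(NS(=O)(=O)c2ccc(N3CCNC3=O)cc2)c1` gives 86 nM

Compound 1 at 58 nM and compound 3 at 86 nM lie within the scatter of each other, and compound 2 at 270 nM stands clearly higher than both. Compound 4 `COc1cc(NS(=O)(=O)c2ccc(N3CCNC3=O)cc2)cc(OC)c1` has not yet been measured. Its change from compound 1 is hydrogen in place of methoxy on an aromatic carbon, ortho to two methoxy groups and para to a large group hydrogen in place of methoxy on an aromatic carbon in all. Among the compounds with values here, no measured step removes a methoxy group. Within the data shown here, the only guide is a step of another kind, 2,5-dimethylphenyl in place of 3-bromophenyl on a sulfonamide nitrogen, which gives a 3.1-fold lower number from compound 2 to compound 3 (0.50 log units; beyond the scatter) and counts as modest. A step of similar modest size is therefore expected in this assay toward a higher number, although the data do not settle the direction. The expected step is a 2.4-fold higher number from compound 1 to compound 4 (0.38 log units; beyond the scatter) on this reasoning. For compound 4 the estimated value is 140 nM within an expected range from 45 nM to 450 nM.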

Compound 4, half-maximal inhibitory concentration: 280 nM
For compound 4 the middle estimate is 2.0-fold (0.30 log units) below the measured one; low and high end bracket the measured number.
By their numbers in this assay, from the lowest: compounds 1 and 3 (each within the scatter of the next); then compounds 2 and 4 (each within the scatter of the next).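

In this assay, hydrogen in place of methoxy on this aromatic carbon gives a 4.8-fold higher number from compound 1 to compound 4 (0.68 log units; beyond the scatter). The earlier compounds shown here offered no step at this position, so this is its first direct reading: the methoxy group ortho to two methoxy groups and para to a large group counts in this assay, and the two methoxy groups that remain in compound 4 do not restore the lower number of compound 1. The step is read at this one position and on this one core, so it says nothing yet about the other methoxy groups.

Going by these compounds, whether another group on this carbon, such as a hydroxyl, an ethoxy group or an amine, would hold the number near that of compound 1 remains open. Why the number rises on this change also remains open, as nothing at hand bears on the cause.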